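A few compounds are considered here, and "the series" means these few. Any claim that something is new, unique, unknown or untested is made for them only; others in the source may bear on it.

Compound 1 `COc1ccc(/C=C/C(=O)c2ccc(OC)c3c2OC(C)(C)C=C3)cc1O`: 630 nM
Compound 2 `CCC(=O)Oc1cc(/C=C/C(=O)c2ccc(OC)c3c2OC(C)(C)C=C3)ccc1OC`: 160 nM
Compound 3 `COc1ccc(/C=C/C(=O)c2ccc(OC)c3c2OC(C)(C)C=C3)cc1CS(C)(=O)=O`: 9240 nM

All three share one core and differ only in one group on a ring at the far end of the chain. In a functional assay on K562 cells (Homo sapiens) for cytotoxicity, read by MTT assay (a higher number here means a weaker inhibitor, a lower number a stronger inhibitor), compound 2 gives the lowest number of the three: compound 1 sits a 3.9-fold lower number from compound 1 to compound 2 (0.60 log units; beyond the scatter) away, and compound 3 lies furthest, at a 58-fold higher number from compound 2 to compound 3 (1.76 log units; beyond the scatter). Compound 4 `COc1ccc(/C=C/C(=O)c2ccc(OC)c3c2OC(C)(C)C=C3)cc1OS(=O)(=O)c1ccc(C)cc1` has not yet been measured; it differs from compound 2 in one place: (4-methylphenyl)sulfonyl in place of propanoyl on an oxygen on an aromatic ring.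

Going by the values given here, two measured steps bear on this change. Putting propanoyl onto the oxygen gave a 3.9-fold lower number from compound 1 to compound 2 (0.60 log units; beyond the scatter), a gain; bringing in a sulfonyl-containing group in place of the propanoyloxy gave a 58-fold higher number from compound 2 to compound 3 (1.76 log units; beyond the scatter), a large loss. Compound 4 keeps the oxygen link of compound 2 but carries a sulfonyl group, so the change is expected to cost potency, though less than the step to compound 3. For compound 4 the expected step is a 9.4-fold higher number from compound 2 to compound 4 (0.97 log units; beyond the scatter), giving an estimate of 1500 nM with a range from 300 nM to 8000 nM.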

Compound 4, half-maximal inhibitory concentration: 7850 nM
The estimate for compound 4 lay 5.2-fold (0.72 log units) below the measured number; the measured number falls inside the stated range.
By their numbers in this assay, from the lowest: compound 2; then compound 1; then compounds 4 and 3 (each within the scatter of the next).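

In this assay the outcome at this oxygen turns on which group is placed there: (4-methylphenyl)sulfonyl in place of hydrogen gives a 12-fold higher number from compound 1 to compound 4 (1.10 log units; beyond the scatter) and in place of propanoyl gives a 49-fold higher number from compound 2 to compound 4 (1.69 log units; beyond the scatter) so the gain seen with propanoyl does not extend to every group on this oxygen. Joining a sulfonyl-containing group through oxygen shows no visible advantage over joining one through carbon, with a 1.2-fold lower number from compound 3 to compound 4 (0.07 log units; within the scatter) leaving the two indistinguishable. No measurement shown here explains the size of these losses.

In compound 4 the sulfonyl and the aromatic ring enter together, and a methylsulfonyl or a benzoyl group on the same oxygen would separate them. On these data alone, how a longer chain such as butanoyl compares with propanoyl also remains open.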